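The source may report more compounds than this note shows. Statements on the series, on what has been measured and on what is new or still open speak of the compounds shown alone.

Compound 3 `CCCCN1CCC(CNC(=O)c2cc(Br)cc3[nH]cnc23)CC1` gives 0.646 nM in an assay on membranes from striatum with 5-hydroxytryptamine receptor 4 (Rattus norvegicus) as the target; on this read-out higher numbers stand for weaker inhibition and lower numbers for stronger inhibition. Among the three measured compounds its number is the highest, though its gap to compound 2 `CCCCCN1CCC(CNC(=O)c2cc(Cl)cc3[nH]cnc23)CC1`, which gives 0.537 nM in this assay, lies within the scatter; only the gap to compound 1 `CS(=O)(=O)NCCN1CCC(CNC(=O)c2cc(Cl)cc3[nH]cnc23)CC1`, which gives 0.11 nM in this assay, lies beyond it. For the measured compounds named here, the one step recorded between measured compounds, a 4.9-fold higher number from compound 1 to compound 2 (0.69 log units; beyond the scatter), concerns a substituent on the saturated chain and not the aromatic part. Compound 4 `CCCCN1CCC(CNC(=O)c2cc(Br)c(N)c3[nH]cnc23)CC1` differs from compound 3 in the aromatic part: amino in place of hydrogen on an aromatic carbon. Going by the values given here, no measured step touches that position, so there is nothing on the ring itself to lean on; the recorded steps only show that changes far from the core move this assay by modest amounts. For compound 4 a small move toward a lower number is expected, a 1.6-fold lower number from compound 3 to compound 4 (0.21 log units; within the scatter), not far beyond the scatter. Compound 4 is estimated at 0.4 nM in this assay, within a range from 0.12 nM to 1.3 nM.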

Compound 4, inhibition constant: 27.5 nM
Compound 4: the middle estimate sits 69-fold (1.84 log units) below what was measured, and the stated range ends below it.
By their numbers in this assay, from the lowest: compound 1; then compounds 2 and 3 (each within the scatter of the next); then compound 4.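

In this assay, for the compounds shown here, this position proves far from indifferent: amino in place of hydrogen gives a 43-fold higher number from compound 3 to compound 4 (1.63 log units; beyond the scatter) and so a large step, whereas the only earlier step, on the saturated chain, was the modest 4.9-fold higher number from compound 1 to compound 2 (0.69 log units; beyond the scatter) and left the aromatic part untouched. Going by these compounds alone, the result is the first sign that this aromatic carbon, ortho to a bromo group and para to a large group, responds strongly to a substituent, with the number moving toward weaker inhibition. No available data account for the size of this step.

The compounds shown leave open whether a fluoro, methyl or hydroxyl group on this carbon would move the number as far as amino does. They also leave open whether the amino step would be the same with chloro in place of bromo, or with the methanesulfonamido chain of compound 1.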